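This account rests on a few compounds, and the source may have more. Where it says the series, first, only, none or still open, it means among the compounds named here.

Measured in a functional assay on BGC-823 cells (Homo sapiens) for antiproliferative activity, read by MTT assay, with a stated time of 48 h; on this read-out higher numbers stand for weaker inhibition and lower numbers for stronger inhibition
- compound 1 `Fc1cccc(F)c1CSc1nnc(-c2cnccn2)s1` gives 18600 nM
- compound 2 `Clc1ccccc1CSc1nnc(-c2cnccn2)n1-c1ccccc1` gives 34700 nM

Compound 2 at 34700 nM lies within the scatter of compound 1 at 18600 nM and the two read as level. Compound 3 `Clc1cccc(CSc2nnc(-c3cnccn3)n2-c2ccccc2)c1` has the same atoms as compound 2, joined differently (3-chlorophenyl in place of 2-chlorophenyl on a saturated chain carbon bound to a sulfur), with 3-chlorophenyl in place of 2-chlorophenyl on a saturated chain carbon bound to a sulfur. For the measured compounds named here, no measured step speaks to this change, so the expected 1.2-fold lower number from compound 2 to compound 3 (0.06 log units; within the scatter) in this assay stays within the scatter, with no direction favoured. Compound 3 is estimated at 30000 nM (expected range 12000 nM to 70000 nM).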

Compound 3, half-maximal inhibitory concentration: 20300 nM
The estimate for compound 3 lay 1.5-fold (0.17 log units) above the measured number, within the range that was stated.
By their numbers in this assay, from the lowest: compounds 1, 3 and 2 (each within the scatter of the next).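

With 3-chlorophenyl in place of 2-chlorophenyl on a saturated chain carbon bound to a sulfur, this assay gives a 1.7-fold lower number from compound 2 to compound 3 (0.23 log units; within the scatter). For the compounds shown here, this is the first measured step at this position, and it leaves the two compounds level. The two chlorobenzyl isomers cannot be told apart here, and no supporting data bear on the result. From the compounds shown here alone, whether an amine or a carboxylic acid in place of the chlorine would shift the number beyond the scatter remains open. So does the outcome of a longer chain at this place.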